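One Chloro Group Across Two Related Cores

The source may report more compounds than this note shows. Statements on the series, on what has been measured and on what is new or still open speak of the compounds shown alone.

Measured in a functional assay on U-87MG ATCC cells (Homo sapiens) for cytotoxicity, read by MTT assay, with a stated time of 72 h; on this read-out higher numbers stand for weaker inhibition and lower numbers for stronger inhibition:
Compound 1 `COc1cc2c(Oc3ccc(NC(=O)c4cc(-c5ccccc5)nc5ccccc45)cc3F)ccnc2cc1OCCCN1CCCCC1` gives 1490 nM.
Compound 2 `COc1cc2c(Oc3ccc(NC(=O)c4cc(-c5cccc(Cl)c5)nc5ccccc45)cc3F)ccnc2cc1OCCCN1CCCCC1` gives 150 nM.
Compound 3 `COc1cc2c(Oc3ccc(NC(=O)c4cc(-c5ccccc5)nc5ccc(F)cc45)cc3F)ccnc2cc1OCCCN1CCCC1` gives 960 nM.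

Compound 2 differs from compound 1 only by chloro in place of hydrogen on an aromatic carbon, and that single change gave a 9.9-fold lower number from compound 1 to compound 2 (1.00 log units; beyond the scatter). Compound 3 rests on a different core; the difference between the cores of compound 1 and compound 3 is not broken down here, and the values of compound 3 and compound 1 sit within the scatter of each other.

Compound 4 `COc1cc2c(Oc3ccc(NC(=O)c4cc(-c5cccc(Cl)c5)nc5ccc(F)cc45)cc3F)ccnc2cc1OCCCN1CCCC1` has not yet been measured. It differs from compound 3 by chloro in place of hydrogen on an aromatic carbon, the same change at the same kind of place as before. Because the earlier step of a 9.9-fold lower number from compound 1 to compound 2 (1.00 log units; beyond the scatter) lay well beyond the scatter, a step of similar size is expected here: an 8.7-fold lower number from compound 3 to compound 4 (0.94 log units; beyond the scatter). Compound 4 is therefore estimated at 110 nM, likely between 40 nM and 350 nM.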

Compound 4, half-maximal inhibitory concentration: 990 nM
Compound 4: the middle estimate sits 9.0-fold (0.95 log units) below what was measured; measured number outside the range, above it.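

In this assay, replacing phenyl with 3-chlorophenyl on the core of compound 3 gave a 1.0-fold higher number from compound 3 to compound 4 (0.01 log units; within the scatter), so the clear change seen on the core of compound 1 did not carry over to this second core. The two results differ by more than repeat measurements would explain: the same change on two cores in this assay, a 9.9-fold lower number (1.00 log units; beyond the scatter) from compound 1 to compound 2 and a 1.0-fold higher number (0.01 log units; within the scatter) from compound 3 to compound 4, 10-fold (1.01 log units) apart, beyond the scatter of two such steps This shows that the effect of this change depends on the core in this pair, but the two cores differ in more than one place, so it does not show which difference matters or why.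

On these data alone, it remains open how bromo or methyl in place of chloro would behave on each core. As far as these compounds go, it is also open whether a core carrying only one of the differences between compound 1 and compound 3 would keep the larger step.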